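Propanoyl to vinylcarbonyl: a first look at compound 3

This account rests on a few compounds, and the source may have more. Where it says the series, first, only, none or still open, it means among the compounds named here.

Measured in a functional assay on K562 cells (Homo sapiens) for inhibition, read by WST assay, with a stated time of 4 days; on this read-out higher numbers stand for weaker inhibition and lower numbers for stronger inhibition:
- compound 1 `CC(C)(C)c1ccc(CN2CCN(S(=O)(=O)Nc3ccc(SCCc4ccccc4)cc3C(=O)O)CC2)cc1`: 18900 nM
- compound 2 `CCC(=O)N1CCN(c2c3ccc(-c4cccc(F)c4)cc3nn2Cc2ccccc2)CC1`: 10400 nM

Compound 2 stands at 10400 nM and compound 1 stands at 18900 nM on this scale. These two values lie within the scatter of each other, so they set no order, and compound 2 can only be described as level with the other measured compound.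

Compound 3 `C=CC(=O)N1CCN(c2c3ccc(-c4cccc(F)c4)cc3nn2Cc2ccccc2)CC1` has not yet been measured. It differs from compound 2 in one place, with vinyl in place of ethyl on a carbonyl carbon, which turns propanoyl into vinylcarbonyl.

Going by the values given here, no measured pair shows this change, so the expectation rests on a judgement of the change alone. A moderate step beyond the scatter is expected in this assay, toward a lower number and so toward stronger inhibition. The expected move, a 2.6-fold lower number from compound 2 to compound 3 (0.41 log units; beyond the scatter), remains an estimate until measured. Compound 3 is estimated at 4000 nM, with an expected range from 1000 nM to 12000 nM in this read-out.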

Compound 3, half-maximal inhibitory concentration: 7700 nM
Beside the measured number, compound 3's estimate is 1.9-fold (0.28 log units) below it; measured number inside the range.
By their numbers in this assay, from the lowest: compounds 3, 2 and 1 (each within the scatter of the next, the first and the last beyond it).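

In this assay, going by these compounds alone, compounds 2 and 3 form the first pair that differs in one place: on a carbonyl carbon whose other neighbour is an amide-type nitrogen in a ring, vinyl in place of ethyl gives a 1.4-fold lower number from compound 2 to compound 3 (0.13 log units; within the scatter). At this position, the double bond that enters with vinyl therefore sets no order between the two compounds, with compound 2 at 10400 nM and compound 3 at 7700 nM standing level on this scale. No supporting measurement is available to bear on this result.

Going by these compounds, the reading rests on a single pair, so it remains open whether ethyl and vinyl also stand level when the rest of the shared core carries other groups. Also open, on these data alone, is how this position responds to groups such as a longer chain, a cyclopropyl ring, a dimethylamino group carried on the vinyl, or a carboxylic acid in place of ethyl or vinyl on the same carbonyl carbon.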